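The source may report more compounds than this note shows. Statements on the series, on what has been measured and on what is new or still open speak of the compounds shown alone.

Working notes on the series in an assay on isolated protein for inhibition of RAC-beta serine/threonine-protein kinase (Homo sapiens), read by mobility shift assay, tested at 30 uM; a higher number here means more inhibition at the concentration tested (going by the name of the read-out), a lower number less inhibition.

Of the compounds shown here, three of the shared core have been measured. Compound 1 `Cc1cc2nn(-c3ccccc3)c(N)c2c(=O)[nH]1` gives 1%. Compound 2 `Nc1c2c(=O)[nH]c(-c3ccccc3)cc2nn1-c1ccccc1` gives -1%. Compound 3 `COc1ccc(-c2cc3nn(-c4ccccc4)c(N)c3c(=O)[nH]2)cc1` gives 0%. On these numbers compound 3 stands among the other two with no gap to either that reaches beyond the scatter; all three values sit close to zero.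

The measured steps are all flat: a number 2 percentage points lower from compound 1 to compound 2 (within the scatter), a number 1 percentage points lower from compound 1 to compound 3 (within the scatter) and a number 1 percentage points higher from compound 2 to compound 3 (within the scatter). Among the compounds with values here, none of them is beyond the scatter, so the series so far shows no sign that the group on this aromatic carbon moves the read-out.

The next step is compound 4 `CN1CCN(c2ccc(-c3cc4nn(-c5ccccc5)c(N)c4c(=O)[nH]3)cc2)CC1`: 4-methylpiperazin-1-yl in place of methoxy on an aromatic carbon. The step 2>3, methoxy in place of hydrogen at the same aromatic carbon, bears most directly on it and was within the scatter. Replacing methoxy by 4-methylpiperazin-1-yl is therefore expected to give no step beyond the scatter, a number 1 percentage points higher from compound 3 to compound 4 (within the scatter). For compound 4 the expected value in this assay is 1%, with a range from -8% to 10%.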

Compound 4, a percentage reported as inhibition, at one concentration (the size of the read-out at that concentration, not a potency): 10%
The estimate for compound 4 lay 9 percentage points below the measured number; measured number inside the range.
By their numbers in this assay, from the lowest: compounds 2, 3, 1 and 4 (each within the scatter of the next, the first and the last beyond it).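

In this assay, within the data shown here, the 4-methylpiperazin-1-yl group on this aromatic carbon gives the first step that clears the scatter, a number 11 percentage points higher from compound 2 to compound 4 (beyond the scatter), and this step is measured against hydrogen at that place. Measured against methoxy, the same group gives a number 10 percentage points higher from compound 3 to compound 4 (within the scatter), so the change from methoxy cannot be told from repeat scatter, and the series supports only a modest difference from hydrogen. Nothing at hand accounts for that difference.

The compounds shown leave open whether the step belongs to the whole 4-methylpiperazin-1-yl group or only to part of it; a morpholin-4-yl, a piperidin-1-yl or a dimethylamino group on the same aromatic carbon would separate these. As far as these compounds go, whether a longer chain ending in an amine at this place would carry the read-out further also remains open.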